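From propoxy to isobutoxy on compound 2

The source may hold more compounds than are shown below. What is called first, only, known or untested is meant among the compounds shown, and "the series" means these compounds.

In a functional assay on the whole organism with Scenedesmus acutus as the target, with a stated time of 20 h (on this read-out lower numbers stand for stronger inhibition and higher numbers for weaker inhibition), compound 1 (`O=C1C2=C(CCCC2)C(=O)N1c1ccc(Cl)cc1F`) gives 240 nM, compound 3 (`CCCOC(=O)c1cc(N2C(=O)C3=C(CCCC3)C2=O)ccc1Cl`) gives 661 nM and compound 2 (`CCCOC(=O)c1cc(N2C(=O)C3=C(CCCC3)C2=O)c(F)cc1Cl`) gives 66.1 nM, the lowest of the three numbers. Compound 4 (`CC(C)COC(=O)c1cc(N2C(=O)C3=C(CCCC3)C2=O)c(F)cc1Cl`) differs from compound 2 by methyl in place of hydrogen on a saturated chain carbon bound to two saturated chain carbons, so propoxy becomes isobutoxy: methyl in place of hydrogen on a saturated chain carbon bound to two saturated chain carbons. The measured steps bear on this only indirectly. Adding the whole propoxycarbonyl group gave a 3.6-fold lower number from compound 1 to compound 2 (0.56 log units; beyond the scatter), and hydrogen in place of fluoro gave a 10-fold higher number from compound 2 to compound 3 (1.00 log units; beyond the scatter). Going by the values given here, both are modest, and neither alters the chain itself, so no measured step shows what a change at this carbon does. A single methyl within the propoxycarbonyl group is expected to move the number less than the whole group did, most likely by no step beyond the scatter, in either direction. The estimated step is a 1.1-fold higher number from compound 2 to compound 4 (0.02 log units; within the scatter). For compound 4 the expected value is 70 nM, with an estimated range of 28 nM to 160 nM.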

Compound 4, half-maximal inhibitory concentration: 407 nM
Beside the measured number, compound 4's estimate is 5.8-fold (0.76 log units) below it; measured number outside the range, above it.
By their numbers in this assay, from the lowest: compound 2; then compounds 1, 4 and 3 (each within the scatter of the next, the first and the last beyond it).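

In this assay, going by these compounds alone, the chain of the ester proved sensitive, which no earlier step could show: methyl in place of hydrogen on a saturated chain carbon bound to two saturated chain carbons gives a step beyond the scatter (a 6.2-fold higher number from compound 2 to compound 4 (0.79 log units; beyond the scatter)). Where the isobutoxycarbonyl group is the one added, the step stays within the scatter (a 1.7-fold higher number from compound 1 to compound 4 (0.23 log units; within the scatter)), so the gain seen with propoxycarbonyl (a 3.6-fold lower number from compound 1 to compound 2 (0.56 log units; beyond the scatter)) depends on the chain and not on the ester alone. Nothing at hand accounts for this sensitivity.

Open, as far as these compounds go, is whether the branch itself or the added carbon drives the step, which a straight butoxy chain at the same place would separate. Also open, from the compounds shown here alone, is how a shorter ethoxy chain or a free carboxylic acid would read here.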